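The source may hold more compounds than are shown below. What is called first, only, known or untested is meant among the compounds shown, and "the series" means these compounds.

In a functional assay on GBM2 cells (Homo sapiens) for antiproliferative activity, read by WST assay, with a stated time of 72 h (on this read-out lower numbers stand for stronger inhibition and higher numbers for weaker inhibition), compound 3 (`O=C(Nc1cccc(Cl)c1)Nc1cc2ncncc2cc1OCc1cccc(Cl)c1`) gives 3500 nM. That value lies within the usual scatter of both neighbouring values: compound 1 (`O=C(Nc1cccc(Cl)c1)Nc1cc2ncncc2cc1OCc1ccccc1Cl`) at 2100 nM and compound 2 (`O=C(Nc1ccc(Cl)c(Cl)c1)Nc1cc2ncncc2cc1OCc1ccccc1F`) at 6000 nM. The next compound, compound 4 (`O=C(Nc1cccc(F)c1)Nc1cc2ncncc2cc1OCc1cccc(Cl)c1`), differs from compound 3 by one swap, fluoro in place of chloro on an aromatic carbon, turning 3-chlorophenyl into 3-fluorophenyl.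

Among the compounds with values here, no measured pair shows this swap directly. Within the data shown here, the only single-place step available, a 1.7-fold higher number from compound 1 to compound 3 (0.22 log units; within the scatter), stays within the scatter, but it concerns another part of the molecule, 3-chlorophenyl in place of 2-chlorophenyl on a saturated chain carbon bound to an oxygen on an aromatic ring. Compound 2 differs from the others in more than one place, so it isolates no single change. With so little evidence, no shift beyond the scatter is expected in this assay. The expected change is a 1.1-fold higher number from compound 3 to compound 4 (0.04 log units; within the scatter), with no firm direction. For compound 4 the estimated value is 3800 nM, with an expected range from 1700 nM to 8500 nM.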

Compound 4, half-maximal inhibitory concentration: 7800 nM
The estimate for compound 4 lay 2.1-fold (0.31 log units) below the measured number; low and high end bracket the measured number.
By their numbers in this assay, from the lowest: compounds 1, 3, 2 and 4 (each within the scatter of the next, the first and the last beyond it).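

The swap from 3-chlorophenyl to 3-fluorophenyl is the only single-place change shown on this aromatic ring, and in this assay it gives a 2.2-fold higher number from compound 3 to compound 4 (0.35 log units; beyond the scatter). The one earlier step, a 1.7-fold higher number from compound 1 to compound 3 (0.22 log units; within the scatter), concerned the other chlorophenyl group and stayed within the scatter, so this is the first sign that the number responds to a change among the compounds shown. Here, exchanging chloro for fluoro at this position modestly weakens inhibition, but nothing measured here explains why.

On these data alone, this rests on a single pair, so it remains open whether the same swap would have a similar effect with a different group at the other end of the molecule. As far as these compounds go, how a methyl group, a methoxy group or a plain hydrogen would compare at this position also remains open.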